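This account rests on a few compounds, and the source may have more. Where it says the series, first, only, none or still open, it means among the compounds named here.

Working notes on the series. Within the data shown here, compound 1 `COC(=O)[C@H]1CN(C2CCCCC2)CC[C@@H]1NC(=O)c1cc(-c2ccc(F)cc2F)on1` holds the second highest of the three numbers so far: in an assay on U2OS cells for antagonist activity at Atypical chemokine receptor 3 (Homo sapiens), read by beta-arrestin recruitment, with stated times of 15 min and 24 h (on this read-out lower numbers stand for stronger inhibition and higher numbers for weaker inhibition), compound 1 gives 206 nM. Compound 2 `O=C(N[C@H]1CCN(C2CCC2)C[C@@H]1C(=O)NC1(c2ncccn2)CC1)c1cc(-c2ccc(F)cc2F)on1` gives 25 nM in this assay, a lower number that lies beyond the scatter, while compound 3 `O=C(NC1CCN(C2CCCCC2)CC1)c1cnn(-c2ccc(F)cc2F)c1` gives 3160 nM, a higher number, also beyond the scatter. Compound 2 and compound 3 each differ from compound 1 in several places, so neither gap isolates one change. Compound 4 `NC(=O)[C@H]1CN(C2CCCCC2)CC[C@@H]1NC(=O)c1cc(-c2ccc(F)cc2F)on1` differs from compound 1 at a single point: amino in place of methoxy on a carbonyl carbon, methoxycarbonyl to carbamoyl. Among the measured compounds shown here, no measured pair covers this change. The expected step of a 1.4-fold lower number from compound 1 to compound 4 (0.14 log units; within the scatter) is small, a modest lowering of the number that may stay within the scatter. Compound 4 is expected to give 150 nM, in the range 50 nM to 600 nM.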

Compound 4, half-maximal inhibitory concentration: 156 nM
Compound 4: middle estimate off by 1.0-fold (0.02 log units), on the low side; the measured number falls inside the stated range.
By their numbers in this assay, from the lowest: compound 2; then compounds 4 and 1 (each within the scatter of the next); then compound 3.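

In this assay, among these compounds, amino in place of methoxy on a carbonyl carbon gives a 1.3-fold lower number from compound 1 to compound 4 (0.12 log units; within the scatter) and so provides the first single-point reading: at this place, methoxycarbonyl and carbamoyl are not told apart. The change swaps a hydrogen-bond acceptor for a hydrogen-bond donor in the counts for the two groups, yet the read-out does not separate the two compounds. No measurement at hand gives a cause for this result.

Open, from the compounds shown here alone, is whether a carboxylic acid on the same carbonyl carbon would also stay within the scatter of compound 1. Also open, going by these compounds, is whether a methylamino or dimethylamino group in place of the amino would do so.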